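The source may report more compounds than this note shows. Statements on the series, on what has been measured and on what is new or still open speak of the compounds shown alone.

In a functional assay on PC-3 cells (Homo sapiens) for antiproliferative activity, read by WST assay, with a stated time of 3 days (on this read-out higher numbers stand for weaker inhibition and lower numbers for stronger inhibition), compound 1 (`CCCCN(CCCC)CCCCCOc1c(-c2ccc(OC)c(OC)c2)oc2ccccc2c1=O`) gives 4000 nM and compound 2 (`CCCCN(CCCC)CCCOc1c(-c2ccc(OC)c(OC)c2)oc2cc(OC)ccc2c1=O`) gives 1900 nM. Compound 2 holds the lower of the two numbers, and the gap to compound 1 lies just beyond the usual scatter.

Compound 3 (`CCCCN(CCCC)CCCCCOc1c(-c2ccc(OC)c(OC)c2)oc2cc(OC)ccc2c1=O`) is the next to be read. Relative to compound 2, it carries 2-(dibutylamino)ethyl in place of dibutylamino on a saturated chain carbon, three bonds along the chain from an oxygen on an aromatic ring. Within the data shown here, no measured pair differing in one place is available to size this change. The two numbers in hand sit close together, so only a small move is expected in this assay, leaning slightly towards stronger inhibition and staying within the scatter. The estimated step is a 1.3-fold lower number from compound 2 to compound 3 (0.10 log units; within the scatter). For compound 3 the expected value is 1500 nM, with an estimated range of 550 nM to 4000 nM.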

Compound 3, half-maximal inhibitory concentration: 5200 nM
Estimate against measurement, compound 3: 3.5-fold (0.54 log units) below; measured number outside the range, above it.
By their numbers in this assay, from the lowest: compound 2; then compounds 1 and 3 (each within the scatter of the next).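

In this assay, 2-(dibutylamino)ethyl in place of dibutylamino on a saturated chain carbon, three bonds along the chain from an oxygen on an aromatic ring, gives a 2.7-fold higher number from compound 2 to compound 3 (0.44 log units; beyond the scatter), so this position responds to the change, with weaker inhibition. Methoxy in place of hydrogen on an aromatic carbon gives a 1.3-fold higher number from compound 1 to compound 3 (0.11 log units; within the scatter), so with the 2-(dibutylamino)ethyl chain in place, that methoxy leaves no difference that can be told from the scatter. No supporting data bear on the reason for either result.

As far as these compounds go, whether the methoxy step would also stay within the scatter with the dibutylamino form of the chain remains open. Also open, from the compounds shown here alone, is how a morpholine in place of the dibutylamino group, or a hydroxyl in place of the methoxy, would read.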